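From 2,4-dichlorobenzyl to 2,4-difluorobenzyl: one untested step

This account rests on a few compounds, and the source may have more. Where it says the series, first, only, none or still open, it means among the compounds named here.

Measured so far in a functional assay on G-361 cells (Homo sapiens) for antiproliferative activity, with a stated time of 72 h; a higher number here means a weaker inhibitor, a lower number a stronger inhibitor:
compound 1 `Cc1ccc(CNc2ncnc3c2ncn3[C@@H]2O[C@H](CO)[C@@H](O)[C@H]2O)cc1`: "not determined" (no result reported)
compound 2 `OC[C@H]1O[C@@H](n2cnc3c(NCc4ccc(Cl)cc4Cl)ncnc32)[C@H](O)[C@@H]1O`: 128000 nM

Among the measured compounds shown here, compound 2, at 128000 nM, holds the only number in this small set, as no result was reported for compound 1, so it cannot yet be ranked against anything. Compound 3 `OC[C@H]1O[C@@H](n2cnc3c(NCc4ccc(F)cc4F)ncnc32)[C@H](O)[C@@H]1O` is still to be measured in this assay. It carries 2,4-difluorophenyl in place of 2,4-dichlorophenyl on a saturated chain carbon bound to a nitrogen on an aromatic ring, and the shared core is unchanged: 2,4-difluorophenyl in place of 2,4-dichlorophenyl on a saturated chain carbon bound to a nitrogen on an aromatic ring. For the measured compounds named here, no measured step offers a guide, so the expectation is loose, and a result within the usual scatter would not be surprising. A moderate move toward stronger inhibition is expected, shown as a 3.2-fold lower number from compound 2 to compound 3 (0.51 log units; beyond the scatter). For compound 3 the estimated value is 40000 nM, with an expected range from 5000 nM to 170000 nM.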

Compound 3, half-maximal inhibitory concentration: > 166000 nM
Compound 3: a limit, no number (the forecaster's own chance of this, stated with the estimate: 20%); middle value at least 4.1-fold (0.61 log units) from the limit.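

In this assay compound 3 gives > 166000 nM, which is a limit of the assay and not a number. Going by these compounds, the change to 2,4-difluorophenyl on a saturated chain carbon bound to a nitrogen on an aromatic ring reads as an at least 1.2-fold higher number from compound 2 to compound 3 (0.11 log units; that floor lies within the scatter), so this swap brought no stronger inhibition into view, and the true size of the step stays unknown. The reading of this step stops at the value the assay reports: the limit of > 166000 nM in this assay, at which 1 of the 3 values shown sits.

Compound 1 gives "not determined" (no result reported), so it adds nothing to the comparison. On these data alone, whether a pyridyl ring or a cyclohexyl ring in place of 2,4-dichlorophenyl, or a longer chain at the same place, would give a clearly lower number than compound 2 remains open.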